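Notes on the chain substituent and acid dissociation

The compounds below may be only part of what the source reports. "The series", "measured", "known", "first", "only" and "open" are said of these compounds alone.

Going by the values given here, compound 1 `CCCN(C1=NCCN1)c1c(Br)cccc1Br` and compound 2 `CC(C)=CCN(C1=NCCN1)c1c(Br)cccc1Br` are the two measured members. In a physicochemical assay for acid dissociation, compound 1 gives 11, and compound 2 gives 10.8, the step being a number 0.20 log units lower from compound 1 to compound 2 (within the scatter); the two numbers lie within the scatter of each other. Compound 3 `Brc1cccc(Br)c1N(Cc1ccccc1)C1=NCCN1` carries the change (phenyl in place of ethyl on a saturated chain carbon bound to a nitrogen on an aromatic ring). Among the compounds with values here, the only measured step also alters the group on the saturated chain carbon bound to the nitrogen on the aromatic ring and stayed within the scatter, so for compound 3 a step no larger than the scatter, if anything downward, is expected: a number 0.30 log units lower from compound 1 to compound 3 (within the scatter). Compound 3 is therefore estimated at 10.7, between 10.2 and 11.2.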

Compound 3, acid dissociation constant: 10.4
Estimate against measurement, compound 3: 0.30 log units above; the measured number falls inside the stated range.
By their numbers in this assay, from the lowest: compound 3; then compounds 2 and 1 (each within the scatter of the next).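

In this assay this position now shows a step beyond the scatter: phenyl in place of ethyl (a number 0.60 log units lower from compound 1 to compound 3 (beyond the scatter)) and phenyl in place of 2-methylprop-1-en-1-yl (a number 0.40 log units lower from compound 2 to compound 3 (beyond the scatter)). Going by these compounds alone, the earlier pair showed no separation at this place, so phenyl is the first group here set apart from both others. Nothing in hand bears on the reason for this step.

A single phenyl compound leaves open whether the step belongs to aromatic rings generally. From the compounds shown here alone, how a longer chain, an amine or a carboxylic acid at this place would read also remains open.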